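The source may hold more compounds than are shown below. What is called first, only, known or untested is meant among the compounds shown, and "the series" means these compounds.

Measured compounds:
Compound 1, `O=C(CCc1nc2ccccc2c(=O)[nH]1)N/N=C/c1ccc(O)c(O)c1`: 40000000 nM
Compound 2, `O=C(CCCc1nc2ccccc2c(=O)[nH]1)N/N=C/c1cc(O)c(O)c(O)c1`: 40000000 nM
Compound 3, `O=C(CCc1nc2ccccc2c(=O)[nH]1)N/N=C/c1ccccc1`: 265000000 nM

In a physicochemical assay, read by spectrophotometry, with a stated time of 6 min (on this read-out higher numbers stand for weaker inhibition and lower numbers for stronger inhibition), compound 1 gives 40000000 nM, level with compound 2 at the digits shown, and together these two are the lowest of the three numbers. Compound 3 stands furthest from compound 1, with a 6.6-fold higher number from compound 1 to compound 3 (0.82 log units; beyond the scatter). For the measured compounds named here, compound 2 carries a longer chain and a third hydroxy group, and its number is no different from that of compound 1 within the scatter, but no single-place step connects the two.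

Compound 4, `COc1cc(/C=N/NC(=O)CCc2nc3ccccc3c(=O)[nH]2)cc(O)c1O`, has not yet been measured. It differs from compound 1 in one place: methoxy in place of hydrogen on an aromatic carbon, sitting ortho to a hydroxy group, meta to a hydroxy group and meta to a large group. Going by the values given here, the only measured step that bears on the ring is the one from compound 1 to compound 3, which removed both hydroxy groups and raised the number beyond the scatter. Compound 4 keeps both hydroxy groups, so that step does not speak for a change; compound 2, which carries an extra oxygen substituent on the same ring, gives a number level with compound 1. Compound 4 is therefore expected to sit close to compound 1, with no change at the digits printed from compound 1 to compound 4 (within the scatter) being no more than the scatter. The estimate for compound 4 in this assay is 40000000 nM, with a range from 20000000 nM to 80000000 nM.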

Compound 4, half-maximal inhibitory concentration: 40000000 nM
Compound 4: the middle estimate sits on the measured number at the digits printed; the measured number falls inside the stated range.
By their numbers in this assay, from the lowest: compounds 1, 2 and 4 (each within the scatter of the next); then compound 3.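

In this assay, the new step gives no change at the digits printed from compound 1 to compound 4 (within the scatter) for methoxy in place of hydrogen on an aromatic carbon, ortho to a hydroxy group, meta to a hydroxy group and meta to a large group. This is the first single-place change shown that keeps both hydroxy groups, whereas the only earlier step on this ring, a 6.6-fold higher number from compound 1 to compound 3 (0.82 log units; beyond the scatter), took both away at once; at this position, then, an entering group of 2 heavy atoms with 1 hydrogen-bond acceptor leaves the number within the scatter of that of compound 1. No measurement shown gives a reason for this result.

The compounds shown leave open whether this position would accept something other than methoxy, such as chlorine, an ethoxy group, an amine or a carboxylic acid. They also leave open what each hydroxy group contributes on its own, as the step to compound 3 removes both together, and what a longer chain does alone, as compound 2 differs from compound 1 in more than one place.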